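A few compounds are considered here, and "the series" means these few. Any claim that something is new, unique, unknown or untested is made for them only; others in the source may bear on it.

Two compounds open this series, compound 1 (`COc1ccccc1/C=C/c1nc2ccccc2c(=O)[nH]1`) and compound 2 (`COc1ccc(/C=C/c2nc3ccccc3c(=O)[nH]2)cc1`), and both carry a methoxy group on the same shared core. Both were tested in a functional assay on A549 cells (Homo sapiens) for antiproliferative activity, with a stated time of 72 h; on this read-out lower numbers stand for stronger inhibition and higher numbers for weaker inhibition. Compound 1 gives > 25000 nM, which is a limit of the assay and not a number. Compound 2 gives > 25000 nM, which is also a limit. The measured picture so far is the limit of > 25000 nM in this assay, at which 2 of the 2 values shown sit, so compound 2 has no exact potency, and neither measurement shows how far it lies from real inhibition.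

The next compound, compound 3 (`CCCCOc1ccc(/C=C/c2nc3ccccc3c(=O)[nH]2)cc1`), changes one place in compound 2, turning methoxy into butoxy: propyl in place of hydrogen on a saturated chain carbon bound to an oxygen on an aromatic ring. For the measured compounds named here, no measured pair yet shows what lengthening this chain does, so the expectation is cautious. In this assay, a modest move towards stronger inhibition is expected, though the result may well stay at the limit. The estimated change is an at least 1.2-fold lower number from compound 2 to compound 3 (0.09 log units; that floor lies within the scatter). For compound 3 the expected value is 20000 nM, with an estimated range of 6000 nM to 50000 nM.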

Compound 3, half-maximal inhibitory concentration: > 25000 nM
Compound 3: no number, only a limit (the forecaster's own chance of this, stated with the estimate: 55%); at least 1.2-fold (0.09 log units) between middle value and limit.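

In this assay compound 3 gives > 25000 nM, which is a limit of the assay and not a number. The step from compound 2 to compound 3 cannot be read, because both results sit at the same limit: the limit of > 25000 nM in this assay, at which 3 of the 3 values shown sit. Whether going from methoxy to butoxy changes inhibition at all, and what exact potency any of these compounds has, stays open.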